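Replacing the 4-ethoxyphenyl group: what compound 3 may show

The compounds below may be only part of what the source reports. "The series", "measured", "known", "first", "only" and "open" are said of these compounds alone.

- compound 1 `CCn1c(C(=O)NCC#N)ccc1C(CC)(CC)c1ccc(OCCC(O)(CC)CC)c(C)c1`: > 50000 nM (a limit)
- compound 2 `CCOc1ccc(NC(=O)c2ccc(C(CC)(CC)c3ccc(OCCC(O)(CC)CC)c(C)c3)n2CC)cc1`: > 50000 nM (a limit)

Both compounds were tested in a functional assay on MCF7 cells (Homo sapiens) for antiproliferative activity, read by MTT assay, with a stated time of 48 h; a lower number here means a stronger inhibitor, a higher number a weaker inhibitor. Neither gave a number, and compound 2 stands only at a limit, > 50000 nM. The same holds across the small set: the limit of > 50000 nM in this assay, at which 2 of the 2 values shown sit.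

Compound 3 `CCn1c(C(=O)N(C)CC(=O)O)ccc1C(CC)(CC)c1ccc(OCCC(O)(CC)CC)c(C)c1` differs from compound 2 in one place: (carboxymethyl)(methyl)amino in place of (4-ethoxyphenyl)amino on a carbonyl carbon. Here (carboxymethyl)(methyl)amino takes the place of (4-ethoxyphenyl)amino on a carbonyl carbon.

Going by the values given here, the one measured step that bears on this change is a step that the two limits leave unreadable from compound 1 to compound 2, where 4-ethoxyphenyl came in place of cyanomethyl on an amide-type nitrogen. It concerns the same part of the molecule, but it has no readable size. It therefore offers no direction and no measure for the new change. With nothing pointing to a gain or a loss, no step beyond the usual scatter is expected, and a further limit is the likeliest report. The expected step is a step that the limit leaves unreadable from compound 2 to compound 3. For compound 3 the estimated value is 60000 nM, with an expected range of 25000 nM to 150000 nM.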

Compound 3, half-maximal inhibitory concentration: 79 nM
Beside the measured number, compound 3's estimate is 760-fold (2.88 log units) above it, and the stated range ends above it.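

The group on the carbonyl carbon can carry a very large effect in this assay: placing (carboxymethyl)(methyl)amino there gives an at least 630-fold lower number from compound 2 to compound 3 (2.80 log units; beyond the scatter), and an at least 630-fold lower number from compound 1 to compound 3 (2.80 log units; beyond the scatter). Both sizes are only minimum sizes because the two earlier compounds reach a limit rather than a number, and for the same reason the step between those two cannot be read: the limit of > 50000 nM in this assay, at which 2 of the 3 values shown sit. So the shared core does not by itself fix the outcome in this series, since compound 3 keeps that core and gives a measured value once this one group is changed.

The change from compound 2 to compound 3 removes the aromatic ring and brings in both the carboxymethyl chain and the methyl on the amide nitrogen, so the compounds shown cannot say which of these parts accounts for the step. As far as these compounds go, a (carboxymethyl)amino group without that methyl, the methyl ester of compound 3, or a longer chain ending in a carboxylic acid would help separate these parts, and how any of them would read in this assay remains open.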